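This account rests on a few compounds, and the source may have more. Where it says the series, first, only, none or still open, it means among the compounds named here.

Compound 2 `Cc1ccc(Nc2ncc([C@H](NC(=O)c3nccs3)C(C)C)cc2Cl)cn1` and compound 1 `Cc1ccc(Nc2ncc([C@@H](NC(=O)c3nccs3)C(C)C)cc2Cl)cn1` share every atom and bond and differ only in the configuration drawn at the saturated chain carbon that carries the amide nitrogen. In a functional assay on HEK293 cells for negative allosteric modulation of metabotropic glutamate receptor 5 (Homo sapiens), read by HTRF and inositol phosphate accumulation (on this read-out lower numbers stand for stronger inhibition and higher numbers for weaker inhibition), compound 1 gives 1060 nM, while compound 2 gives 7.5 nM. For the measured compounds named here, the step is a 140-fold lower number from compound 1 to compound 2 (2.15 log units; beyond the scatter), and the only thing that changes between them is the fact that compounds 1 and 2 differ only in the configuration as drawn. Among the two measured numbers, compound 2 stands lowest, with compound 1 far above it.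

Compound 3 `Cc1ccc(Nc2ncc([C@H](NC(=O)c3nccs3)C3CCCCC3)cc2Cl)cn1` keeps the configuration of compound 2 and changes only the side group: cyclohexyl in place of isopropyl on a saturated chain carbon bound to an amide-type nitrogen and an aromatic carbon. Going by the values given here, the single measured step concerns configuration, not the size of this group, so it offers no direct guide to the present change; it shows only that the carbon in question is sensitive to how its substituents are arranged. Among the compounds with values here, with no measured step on the isopropyl-to-cyclohexyl exchange, the expectation rests on compound 2 alone and is held loose. The step from compound 2 to compound 3 is expected to be a 2.0-fold higher number from compound 2 to compound 3 (0.30 log units; within the scatter), with no firm direction. Compound 3 is therefore estimated at 15 nM, within a range from 3 nM to 100 nM.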

Compound 3, half-maximal inhibitory concentration: 37.8 nM
Compound 3: the middle estimate sits 2.5-fold (0.40 log units) below what was measured; the range from low to high includes it.
By their numbers in this assay, from the lowest: compound 2; then compound 3; then compound 1.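

Swapping the isopropyl side group for cyclohexyl gives, in this assay, a 5.0-fold higher number from compound 2 to compound 3 (0.70 log units; beyond the scatter). The earlier pair showed only that the arrangement of the groups on this carbon matters; this step shows that the identity of the side group matters as well, although the effect is much smaller than a 140-fold lower number from compound 1 to compound 2 (2.15 log units; beyond the scatter). The only explanatory fact at hand concerns configuration and does not bear on this exchange of side groups.

The number of carbon atoms and the presence of a ring change together in this step, so the compounds shown cannot tell which of the two goes with the higher number; a cyclopropyl or a tert-butyl group on the same carbon would pull these apart. Nor do they tell whether the drawn configuration matters as much with cyclohexyl on this carbon as it does with isopropyl.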